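Fluoro to hydroxy: working notes on the series

The compounds below may be only part of what the source reports. "The series", "measured", "known", "first", "only" and "open" are said of these compounds alone.

- compound 1 `CC(=O)N1N=C(c2ccc3ccccc3c2)OC1c1ccccc1`: 2.43 ug/mL
- compound 2 `CC(=O)N1N=C(c2ccc3ccccc3c2)OC1c1ccc(Cl)cc1`: 2.63 ug/mL
- compound 3 `CC(=O)N1N=C(c2ccc3ccccc3c2)OC1c1ccccc1F`: 3.44 ug/mL

In a functional assay on MCF7 cells (Homo sapiens) for antiproliferative activity, read by MTT assay, with a stated time of 48 h (a lower number here means a stronger inhibitor, a higher number a weaker inhibitor), compound 3 gives 3.44 ug/mL, which is within the scatter of the other two values. Next is compound 4 `CC(=O)N1N=C(c2ccc3ccccc3c2)OC1c1ccccc1O`, with hydroxy in place of fluoro on an aromatic carbon, ortho to a large group (hydroxy in place of fluoro on an aromatic carbon).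

The nearest evidence is a 1.4-fold higher number from compound 1 to compound 3 (0.15 log units; within the scatter), where fluoro replaces hydrogen. The others are a 1.1-fold higher number from compound 1 to compound 2 (0.03 log units; within the scatter) and a 1.3-fold higher number from compound 2 to compound 3 (0.12 log units; within the scatter). All three lie within the scatter, but none involves hydroxy. No step beyond the scatter is therefore expected, and no direction is favoured.

The estimated step is a 1.1-fold lower number from compound 3 to compound 4 (0.06 log units; within the scatter). For compound 4 the expected value is 3 ug/mL, with an estimated range of 1.4 ug/mL to 6.2 ug/mL.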

Compound 4, half-maximal inhibitory concentration: 2.12 ug/mL
Compound 4: the middle estimate sits 1.4-fold (0.15 log units) above what was measured; the measured number falls inside the stated range.
By their numbers in this assay, from the lowest: compounds 4, 1, 2 and 3 (each within the scatter of the next).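

In this assay hydroxy at this position, ortho to a large group, gives (a 1.6-fold lower number from compound 3 to compound 4 (0.21 log units; within the scatter)) against fluoro, (a 1.1-fold lower number from compound 1 to compound 4 (0.06 log units; within the scatter)) against hydrogen and (a 1.2-fold lower number from compound 2 to compound 4 (0.09 log units; within the scatter)) against the 4-chlorophenyl compound, so none of these changes leaves the scatter. Bringing in a hydrogen-bond donor and acceptor here thus produces no step beyond the scatter. Nothing available explains these small differences.

From the compounds shown here alone, whether an amine, a methoxy group or a carboxylic acid at this position would leave the scatter stays open. Also open, going by these compounds, is whether hydroxy elsewhere on this ring would behave alike.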